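The source may hold more compounds than are shown below. What is called first, only, known or untested is meant among the compounds shown, and "the series" means these compounds.

Going by the values given here, compound 3 `COC(=O)[C@@]1(C)CC[C@@H]2C3=C1CC[C@@H](C)[C@]3(C)C[C@@H]1c3cccc(Br)c3N[C@H]21` carries a bromo group on one aromatic carbon of the shared core, and in a functional assay on HBL-100 cells (Homo sapiens) for inhibition, read by sulforhodamine B assay, with a stated time of 48 h (a higher number here means a weaker inhibitor of growth, a lower number a stronger inhibitor of growth), compound 3 gives 40000 nM, the second highest of the three numbers measured so far. Compound 2 `COC(=O)[C@@]1(C)CC[C@@H]2C3=C1CC[C@@H](C)[C@]3(C)C[C@@H]1c3cccc(C)c3N[C@H]21`, which carries a methyl group at the same position, gives 32000 nM in this assay. The gap between them is small: a 1.3-fold higher number from compound 2 to compound 3 (0.10 log units; within the scatter). Compound 1 `COC(=O)[C@@]1(C)CC[C@@H]2C3=C1CC[C@@H](C)[C@]3(C)C[C@@H]1c3ccccc3N[C@H]21`, with hydrogen at that position, gives 78000 nM in this assay, and stands furthest from compound 3. Going from the unsubstituted compound to either substituted one lowered the number: a 2.4-fold lower number from compound 1 to compound 2 (0.39 log units; beyond the scatter), and a 2.0-fold lower number from compound 1 to compound 3 (0.29 log units; within the scatter).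

Compound 4 `COC(=O)[C@@]1(C)CC[C@@H]2C3=C1CC[C@@H](C)[C@]3(C)C[C@@H]1c3cccc(Cl)c3N[C@H]21` takes the next step, (chloro in place of bromo on an aromatic carbon). The relevant experience is that a methyl group and a bromo group at this carbon gave numbers within the scatter of each other, and each gave a modest or within-scatter drop from hydrogen. Swapping one such group for another of similar kind is therefore expected to produce little movement in this assay, with no step beyond the scatter. For compound 4 the expected change is a 1.1-fold lower number from compound 3 to compound 4 (0.05 log units; within the scatter). Compound 4 is estimated at 36000 nM, with a likely range from 18000 nM to 75000 nM.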

Compound 4, concentration for 50% growth inhibition: 52000 nM
Compound 4: middle estimate off by 1.4-fold (0.16 log units), on the low side, within the range that was stated.
By their numbers in this assay, from the lowest: compounds 2, 3, 4 and 1 (each within the scatter of the next, the first and the last beyond it).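

In this assay, chloro in place of bromo on this aromatic carbon leaves the number within the scatter (a 1.3-fold higher number from compound 3 to compound 4 (0.11 log units; within the scatter)), so the two halogens cannot be told apart at this position. Chloro cannot be separated from methyl either (a 1.6-fold higher number from compound 2 to compound 4 (0.21 log units; within the scatter)), nor, on this reading, from hydrogen (a 1.5-fold lower number from compound 1 to compound 4 (0.18 log units; within the scatter)). Of the three groups tried at this carbon, only methyl, in compound 2, now stands beyond the scatter from hydrogen, while bromo and chloro do not, so the effect of putting a small group here looks slight and shows no clear order among methyl, bromo and chloro.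

Still open, going by these compounds, is how the shared core responds to a group of a different kind on this carbon, such as an amine, a carboxylic acid or a longer chain, and whether any of these would move the number well beyond the scatter. Nothing measured here explains why methyl, bromo and chloro sit so close together.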